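A few compounds are considered here, and "the series" means these few. Any claim that something is new, unique, unknown or untested is made for them only; others in the source may bear on it.

In a functional assay on NFS-60 cells (Mus musculus) for inhibition, with a stated time of 72 h (a lower number here means a stronger inhibitor of growth, a higher number a weaker inhibitor of growth), compound 1 `Nc1ncnc2c(C(=O)Nc3cccc4c3c(Br)nn4Cc3ccccn3)csc12`, with pyridin-2-yl on a saturated chain carbon bound to an aromatic nitrogen, gives 2500 nM. Compound 2 `CCn1nc(Cn2nc(Br)c3c(NC(=O)c4csc5c(N)ncnc45)cccc32)cc1C(C)C`, with 1-ethyl-5-isopropyl-1H-pyrazol-3-yl on that carbon, gives 62 nM, the lower of the two numbers. Compound 3 `C#CCn1nc(Br)c2c(NC(=O)c3csc4c(N)ncnc34)cccc21` has not yet been measured. It differs from compound 2 at the same place: ethynyl in place of 1-ethyl-5-isopropyl-1H-pyrazol-3-yl on a saturated chain carbon bound to an aromatic nitrogen. In words, ethynyl stands in place of 1-ethyl-5-isopropyl-1H-pyrazol-3-yl, which turns (1-ethyl-5-isopropyl-1H-pyrazol-3-yl)methyl into propargyl.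

Among the compounds with values here, only one measured step bears on this change: a 40-fold lower number from compound 1 to compound 2 (1.61 log units; beyond the scatter). Within the data shown here, it shows that the number in this assay can move strongly with the group at this place, but no measured compound carries ethynyl there. Among the measured compounds shown here, compound 2 holds the lowest number so far, so a rise beyond the scatter is expected, probably smaller than the measured step. The expected step is a 9.7-fold higher number from compound 2 to compound 3 (0.99 log units; beyond the scatter). The estimate for compound 3 is 600 nM, with an expected range from 120 nM to 3000 nM.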

Compound 3, concentration for 50% growth inhibition: > 10000 nM
Compound 3: no number, only a limit; the forecaster's own chance of this, stated with the estimate: 3%; at least 16-fold (1.22 log units) between middle value and limit.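

The entry for compound 3 in this assay is a limit of the assay and not a number: the limit of > 10000 nM in this assay, at which 1 of the 3 values shown sits. Even so, the limit can be read as a step at this place, an at least 160-fold higher number from compound 2 to compound 3 (2.20 log units; beyond the scatter), and it also sets ethynyl apart from pyridin-2-yl, with an at least 4.0-fold higher number from compound 1 to compound 3 (0.60 log units; beyond the scatter). Where the earlier pair showed only that one aromatic ring on this saturated chain carbon can give a much lower number than another, a 40-fold lower number from compound 1 to compound 2 (1.61 log units; beyond the scatter), the new result adds a group with no ring, and among these three compounds it is the one with the highest entry, with no compound going against that order.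

The compounds shown leave open how far compound 3 really lies from the other two, and whether the ring itself matters or the atoms it carries, since the two ring groups differ in both their ring and their substituents. A plain phenyl, a saturated cyclohexyl ring or a longer alkyl chain such as n-butyl on the same carbon would separate these readings, as would the pyrazole without its ethyl or isopropyl group.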